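The compounds below may be only part of what the source reports. "The series", "measured", "known", "first", "only" and "open" are said of these compounds alone.

Compound 1 `CC(=O)c1cc(-c2ccc(F)cc2)cc2cc(-c3ccccc3)[nH]c12` carries a 4-fluorophenyl group and a phenyl group on the shared core. In a functional assay on HeLa cells (Homo sapiens) for cytotoxicity, read by MTT assay, with a stated time of 2 days, tested at 10 uM (a lower number here means a stronger effect, a higher number a weaker effect of the compound at the concentration tested), compound 1 gives 55.7%. Compound 2 `COc1ccc(-c2cc(C(C)=O)c3[nH]c(-c4ccccc4)cc3c2)cc1` differs from compound 1 by methoxy in place of fluoro on an aromatic carbon; in this assay compound 2 gives 33.9%, and a number 21.8 percentage points lower from compound 1 to compound 2 (beyond the scatter). Compound 3 `COc1ccc(-c2cc3cc(-c4ccc(F)cc4)cc(C(C)=O)c3[nH]2)cc1` differs from compound 1 by methoxy in place of hydrogen on an aromatic carbon, and this is also how the core of compound 3 differs from the core of compound 1. In this assay compound 3 gives 52%, and a number 3.7 percentage points lower from compound 1 to compound 3 (within the scatter), so these two values cannot be told apart.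

Compound 4 `COc1ccc(-c2cc(C(C)=O)c3[nH]c(-c4ccc(OC)cc4)cc3c2)cc1` has not yet been measured in this assay. It differs from compound 3 by methoxy in place of fluoro on an aromatic carbon. This is the same change that turns compound 1 into compound 2, and in both cases the place reads the same: on an aromatic carbon of a six-membered aromatic ring of carbon only, para to a large group. Among the four compounds this change occurs twice in all. Among the compounds with values here, because the step of a number 21.8 percentage points lower from compound 1 to compound 2 (beyond the scatter) lowered the read-out beyond the scatter, a step in the same direction is expected from compound 3 to compound 4, although with only one earlier example its exact size remains uncertain. The step expected here is a number 17 percentage points lower from compound 3 to compound 4 (beyond the scatter). Compound 4 is thus expected to give about 35% in this assay, with a likely range from 20% to 50%.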

Compound 4, a percentage reported as activity, at one concentration (the size of the read-out at that concentration, not a potency): 37.1%
Estimate against measurement, compound 4: 2.1 percentage points below; the range from low to high includes it.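

In this assay, the change from 4-fluorophenyl to 4-methoxyphenyl carries over to a second core, with a number 14.9 percentage points lower from compound 3 to compound 4 (beyond the scatter), and this step agrees with the earlier one in direction and closely enough in size: the same change on two cores in this assay, a number 21.8 percentage points lower (beyond the scatter) from compound 1 to compound 2 and a number 14.9 percentage points lower (beyond the scatter) from compound 3 to compound 4, 6.9 percentage points apart, within the scatter of two such steps. The other change, methoxy in place of hydrogen, gives no readable difference on either core, with a number 3.2 percentage points higher from compound 2 to compound 4 (within the scatter), and here too the two cores agree: the same change on two cores in this assay, a number 3.7 percentage points lower (within the scatter) from compound 1 to compound 3 and a number 3.2 percentage points higher (within the scatter) from compound 2 to compound 4, 6.9 percentage points apart, within the scatter of two such steps. Within the data shown here, this agreement rests on only two cores and on a read-out at a single concentration, which is not a potency, so it does not show why either change acts as it does or whether the same steps would appear on a core outside these four compounds.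

The compounds shown carry only fluoro, methoxy or hydrogen on an aromatic carbon of a six-membered aromatic ring of carbon only, para to a large group, so it remains open what an amine, a carboxylic acid or a longer chain such as butoxy would do there. All four also keep the same acetyl group, which leaves open how an amide or a nitrile in its place would read in this assay.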